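Swapping Iodo for Methoxy: What Growth Inhibition to Expect

The source may report more compounds than this note shows. Statements on the series, on what has been measured and on what is new or still open speak of the compounds shown alone.

In a functional assay on MDA-MB-468 cells (Homo sapiens) for antiproliferative activity (on this read-out lower numbers stand for stronger inhibition of growth and higher numbers for weaker inhibition of growth), compound 1 (`COc1ccc(-c2nc3cc(F)ccc3s2)cc1C`) gives 58 nM while compound 2 (`COc1ccc(-c2nc3cc(F)ccc3s2)cc1Br`) gives 420 nM and compound 3 (`COc1ccc(-c2nc3cc(F)ccc3s2)cc1I`) gives 360 nM as its value. Compound 3 therefore sits with compound 2, well above compound 1. Compound 4 (`COc1ccc(-c2nc3cc(F)ccc3s2)cc1OC`) has methoxy in place of iodo on an aromatic carbon. Among the compounds with values here, no methoxy compound has been measured, so the evidence is indirect. Replacing methyl with a halogen raised the number (a 7.2-fold higher number from compound 1 to compound 2 (0.86 log units; beyond the scatter)) and (a 6.2-fold higher number from compound 1 to compound 3 (0.79 log units; beyond the scatter)), both modest, while swapping one halogen for the other (a 1.2-fold lower number from compound 2 to compound 3 (0.07 log units; within the scatter)) stays within the scatter. Removing the iodo may win back a similar amount. The expected step (a 6.0-fold lower number from compound 3 to compound 4 (0.78 log units; beyond the scatter)) is a modest fall in the number in this assay with real uncertainty. For compound 4 the estimated value is 60 nM with an expected range from 5 nM to 400 nM for now.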

Compound 4, concentration for 50% growth inhibition: < 0.1 nM
Compound 4 gave a limit, no number; the forecaster's own chance of this, stated with the estimate: 10%; middle value at least 600-fold (2.77 log units) away from the limit.
By their numbers in this assay, from the lowest: compound 1; then compounds 3 and 2 (each within the scatter of the next). At a limit, below all of these: compound 4.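

In this assay, compound 4 reads < 0.1 nM, which is a limit of the assay and not a number. Methoxy at this position, ortho to a methoxy group, gives a far lower number than any of the three earlier groups: an at least 3600-fold lower number from compound 3 to compound 4 (3.55 log units; beyond the scatter), an at least 4200-fold lower number from compound 2 to compound 4 (3.62 log units; beyond the scatter) and an at least 580-fold lower number from compound 1 to compound 4 (2.76 log units; beyond the scatter). The earlier compounds shown here spanned only a modest range, so they did not reveal how strongly growth inhibition can depend on the group placed here.

Going by these compounds, the true size of these steps stays open. So does whether a hydroxyl, an ethoxy group or an amine at this position would match methoxy.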